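The source may hold more compounds than are shown below. What is called first, only, known or untested is meant among the compounds shown, and "the series" means these compounds.

Three compounds have numbers in a physicochemical assay for lipophilicity, read by HPLC, measured as octanol-water partition, at pH 2; a higher number here means a more lipophilic compound, a lower number a more polar compound. Compound 1 `O=C(Cn1ccccc1=O)Nc1cc2cccccc-2c1` gives 2. Compound 2 `CN(C)C(=O)c1cn(C)c2ccccc12` gives 1.8. Compound 3 `NC(=O)C1CCN(C(=O)c2cccc3ccccc23)CC1` gives 1.3. On these three numbers compound 2 stands second highest: its nearest neighbour is compound 1, whose number lies higher by an amount within the usual scatter of repeated measurements, so the two cannot be told apart; the furthest is compound 3, whose number lies lower by an amount beyond that scatter. Among the compounds with values here, no pair among the measured compounds differs in only one place, so no single structural change has yet been tied to a shift in this assay.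

Compound 4 `COC(=O)c1ccc2c(C(=O)N(C)C)cn(C)c2c1` has not been measured. It differs from compound 2 in one place: methoxycarbonyl in place of hydrogen on an aromatic carbon. A hydrogen leaves and a methoxycarbonyl group enters on an aromatic carbon of the fused ring system. Within the data shown here, nothing among the measured compounds shows what such a change does in this assay, so the expectation rests on the change alone. The step expected here is a number 0.10 log units higher from compound 2 to compound 4 (within the scatter), which is no shift beyond the scatter. Compound 4 is estimated at 1.9, with a range from 1.5 to 2.3.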

Compound 4, distribution coefficient: 1.9
Estimate against measurement, compound 4: no gap at the digits printed; measured number inside the range.
By their numbers in this assay, from the lowest: compound 3; then compounds 2, 4 and 1 (each within the scatter of the next).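

The first step tied to a single structural change in this assay is a number 0.10 log units higher from compound 2 to compound 4 (within the scatter), where methoxycarbonyl takes the place of hydrogen on an aromatic carbon of the six-membered ring of carbon only. The two compounds cannot be told apart in this assay, so at this one position on this core, adding a group of several heavy atoms, with hydrogen-bond acceptors and no net charge, leaves the number indistinguishable from that of the compound carrying hydrogen. No measured evidence bears on why the number behaves this way here.

From the compounds shown here alone, this single pair speaks for one group at one position, so it remains open whether an amine, a carboxylic acid or a longer chain on the same carbon would also stay within the scatter or would move the number beyond it. Going by these compounds, it also remains open whether methoxycarbonyl would give the same result on another carbon of this ring, or on the core of compound 1 or compound 3.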